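Aromatic substituent step from compound 3 to compound 4

The source may hold more compounds than are shown below. What is called first, only, known or untested is meant among the compounds shown, and "the series" means these compounds.

Compound 1 `NS(=O)(=O)NCCC1CCN(c2cc(-c3ccccc3)ncn2)CC1` carries hydrogen on the aromatic carbon of interest. In a functional assay on M21 cells (Homo sapiens) for antiproliferative activity, read by sulforhodamine B assay, with a stated time of 48 h (a lower number here means a stronger inhibitor of growth, a higher number a weaker inhibitor of growth), compound 1 gives > 100000 nM, which is a limit of the assay and not a number (the limit of > 100000 nM in this assay, at which 1 of the 3 values shown sits). Compound 2 `Cc1ccc(-c2cc(N3CCC(CCNS(N)(=O)=O)CC3)ncn2)cc1`, with methyl on that carbon, gives 57600 nM in this assay; compound 3 `CC(C)(C)c1ccc(-c2cc(N3CCC(CCNS(N)(=O)=O)CC3)ncn2)cc1`, with tert-butyl there, gives 18400 nM. Among the numbers shown, compound 3 stands lowest; the nearest value is that of compound 2, and the remaining entry is a limit. The measured steps are an at least 1.7-fold lower number from compound 1 to compound 2 (0.23 log units; that floor lies within the scatter), an at least 5.4-fold lower number from compound 1 to compound 3 (0.73 log units; beyond the scatter) and a 3.1-fold lower number from compound 2 to compound 3 (0.50 log units; beyond the scatter). The change now followed is chloro in place of tert-butyl on an aromatic carbon, which gives compound 4 `NS(=O)(=O)NCCC1CCN(c2cc(-c3ccc(Cl)cc3)ncn2)CC1`. All three measured steps bear on it, since each alters the same aromatic carbon, and they run toward lower numbers as the group there grows from hydrogen through methyl to tert-butyl. Chloro, with one heavy atom against four, sits nearer to methyl than to tert-butyl in this respect, so in this assay a step back toward higher numbers is expected, of a size close to a 3.1-fold lower number from compound 2 to compound 3 (0.50 log units; beyond the scatter) in reverse. For compound 4 a number of 45000 nM is estimated, within 15000 nM to 100000 nM, corresponding to the expected step of a 2.4-fold higher number from compound 3 to compound 4 (0.39 log units; beyond the scatter).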

Compound 4, concentration for 50% growth inhibition: 45200 nM
Estimate against measurement, compound 4: 1.0-fold (0.00 log units) below; low and high end bracket the measured number.
By their numbers in this assay, from the lowest: compound 3; then compounds 4 and 2 (each within the scatter of the next). At a limit, above all of these: compound 1.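

In this assay, chloro in place of methyl gives a 1.3-fold lower number from compound 2 to compound 4 (0.11 log units; within the scatter), so these two groups read alike at this aromatic carbon, whereas chloro and tert-butyl stay apart, with a 2.5-fold higher number from compound 3 to compound 4 (0.39 log units; beyond the scatter). Chloro in place of hydrogen gives an at least 2.2-fold lower number from compound 1 to compound 4 (0.34 log units; beyond the scatter), and compound 3 now has steps beyond the scatter to each of the other three compounds, which makes it the strongest inhibitor of growth among the four, with tert-butyl the only group here that separates from the others at this carbon. Compound 1 stands at a limit and not at a number, so its steps give only a floor: the limit of > 100000 nM in this assay, at which 1 of the 4 values shown sits.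

On these data alone, the groups on this aromatic carbon are limited to hydrogen, methyl, tert-butyl and chloro, so it remains open how an amine, a carboxylic acid or a methoxy group would read in this assay. As far as these compounds go, it also remains open whether a group such as trifluoromethyl would read with chloro and methyl or with tert-butyl, and whether a longer chain such as n-butyl would track tert-butyl.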